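The source may hold more compounds than are shown below. What is called first, only, known or untested is meant among the compounds shown, and "the series" means these compounds.

Of the compounds shown here, two have so far been measured in a functional assay for inhibition, read by spectrophotometry, with a stated time of 20 min, tested at 4 mg/mL; a higher number here means a stronger effect of the compound at the concentration tested, a lower number a weaker effect. Compound 1 `CC(=O)c1ccc(NC(=O)C(CC(C)C)N(C(=O)c2ccccc2)S(=O)(=O)c2ccc(C)cc2)cc1` gives 67.3%, and compound 2 `CC(=O)c1ccc(NC(=O)CN(C(=O)c2ccccc2)S(=O)(=O)c2ccccc2)cc1` gives 40.9%. Compound 2 thus stands lowest of the two numbers; its nearest neighbour, compound 1, lies higher by a gap that is beyond the usual scatter of repeated measurements.

Compound 3 `CC(=O)c1ccc(NC(=O)C(CC(C)C)N(C(=O)c2ccccc2)S(=O)(=O)c2ccccc2)cc1` has not yet been measured. It differs from compound 2 in a single place: isobutyl in place of hydrogen on a saturated chain carbon bound to an amide-type nitrogen and a carbonyl carbon. Among the measured compounds shown here, compound 1 carries the same isobutyl group, but it also differs from compound 2 at a second place, so its higher number cannot be credited to the isobutyl group alone, and no step between measured compounds that differ in one place is available.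

Because compound 1 gives 67.3% and carries the same isobutyl group, the step is expected to be upward and of moderate size, a number 17.1 percentage points higher from compound 2 to compound 3 (beyond the scatter), though this rests on one comparison only. Compound 3 is accordingly estimated at 58% in this assay, with a range from 40% to 75%.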

Compound 3, a percentage reported as inhibition, at one concentration (the size of the read-out at that concentration, not a potency): 46.9%
The estimate for compound 3 lay 11.1 percentage points above the measured number; the measured number falls inside the stated range.
By their numbers in this assay, from the lowest: compounds 2 and 3 (each within the scatter of the next); then compound 1.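

In this assay, isobutyl in place of hydrogen on a saturated chain carbon bound to an amide-type nitrogen and a carbonyl carbon gives a number 6 percentage points higher from compound 2 to compound 3 (within the scatter), so this single change does not separate the two compounds. The gap that compound 1 showed earlier now goes with the other place: hydrogen in place of methyl on an aromatic carbon gives a number 20.4 percentage points lower from compound 1 to compound 3 (beyond the scatter), a modest step but one that clears the scatter, which the isobutyl step does not. No other measurement bears on why either step has the size it has.

Still open, on these data alone, is whether the methyl on the aromatic carbon would give a step of similar size on a compound that carries hydrogen rather than isobutyl on the saturated chain carbon, since the methyl step has been read only with isobutyl present. Also open, as far as these compounds go, is how the number responds at that chain carbon to groups other than isobutyl, such as a longer chain, a benzyl group, an amine or a carboxylic acid.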